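Changing the amide substituent on a nitrobenzofurazan thioether ester

The source may report more compounds than this note shows. Statements on the series, on what has been measured and on what is new or still open speak of the compounds shown alone.

Measured so far in a functional assay on HOS cells (Homo sapiens) for inhibition, read by MTT assay, with a stated time of 72 h; on this read-out lower numbers stand for stronger inhibition and higher numbers for weaker inhibition:
- compound 1, `Cc1ccccc1NC(=O)CCC(=O)OCCCCCCSc1ccc([N+](=O)[O-])c2nonc12`: compound 1 gives 4020 nM
- compound 2, `COc1ccc(NC(=O)CCC(=O)OCCCCCCSc2ccc([N+](=O)[O-])c3nonc23)cc1`: compound 2 gives 1800 nM

Within the data shown here, compound 2 has the lowest number of the two measured compounds; the one measured step is a 2.2-fold lower number from compound 1 to compound 2 (0.35 log units; beyond the scatter). Compound 3, `CN(C)CCCNC(=O)CCC(=O)OCCCCCCSc1ccc([N+](=O)[O-])c2nonc12`, carries the change (3-(dimethylamino)propyl in place of 4-methoxyphenyl on an amide-type nitrogen). Among the measured compounds shown here, no measured step covers an exchange of this kind, since the step from compound 1 to compound 2 swaps one ring-bearing group for another, so it offers only a loose guide. Compound 3 is therefore expected to land near compound 2, with a wide range, as a 1.4-fold higher number from compound 2 to compound 3 (0.14 log units; within the scatter). The estimate for compound 3 is 2500 nM, between 800 nM and 8000 nM.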

Compound 3, half-maximal inhibitory concentration: 1850 nM
The estimate for compound 3 lay 1.4-fold (0.13 log units) above the measured number; the range from low to high includes it.
By their numbers in this assay, from the lowest: compounds 2 and 3 (each within the scatter of the next); then compound 1.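

In this assay, the amide nitrogen accepts a chain with no ring: 3-(dimethylamino)propyl in place of 4-methoxyphenyl gives a 1.0-fold higher number from compound 2 to compound 3 (0.01 log units; within the scatter) and so no change beyond the scatter. In place of 2-methylphenyl, the same chain gives a 2.2-fold lower number from compound 1 to compound 3 (0.34 log units; beyond the scatter) and so a modest gain. Nothing available explains why such different groups read alike here. Still open, going by these compounds, is whether the dimethylamino end matters, which a plain propyl chain would test. A longer chain or a carboxylic acid on this nitrogen could also show how much change this position accepts.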